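The source may hold more compounds than are shown below. What is called first, only, known or untested is meant among the compounds shown, and "the series" means these compounds.

Compound 1 `COc1ccccc1NC(=S)N/N=C/c1ccc2ccccc2n1` gives > 100000 nM in a functional assay on SGC-7901 cells (Homo sapiens) for antiproliferative activity, read by sulforhodamine B assay, with a stated time of 72 h (a higher number here means a weaker inhibitor, a lower number a stronger inhibitor), and that value is a limit of the assay rather than a number. Compound 2 `Cc1ccc(NC(=S)N/N=C/c2ccc3ccccc3n2)cc1` gives 92900 nM in this assay. The step of an at least 1.0-fold lower number from compound 1 to compound 2 (0.03 log units; that floor lies within the scatter) rests on a floor, since one side sits at the limit of > 100000 nM in this assay, at which 1 of the 2 values shown sits. Compound 2 therefore holds the only number shown; the one other value is a limit.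

Compound 3 `COc1cccc(NC(=S)N/N=C/c2ccc3ccccc3n2)c1` differs from compound 2 in one place: 3-methoxyphenyl in place of 4-methylphenyl on an amide-type nitrogen. Among the measured compounds shown here, the only measured step that bears on this change is the one from compound 1 to compound 2, in which a methoxyphenyl gave way to a methylphenyl on the same nitrogen, and that step was at most a floor within the scatter. Returning a methoxyphenyl, now in the 3-position, is therefore expected to bring no step in this assay beyond the scatter, with some chance that the assay again reports only a limit. Compound 3 is thus expected to give about 95000 nM, within a range from 40000 nM to 250000 nM, an estimated step of a 1.0-fold higher number from compound 2 to compound 3 (0.01 log units; within the scatter).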

Compound 3, half-maximal inhibitory concentration: 79400 nM
Beside the measured number, compound 3's estimate is 1.2-fold (0.08 log units) above it; low and high end bracket the measured number.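

In this assay, 3-methoxyphenyl in place of 4-methylphenyl on the amide-type nitrogen gives a 1.2-fold lower number from compound 2 to compound 3 (0.07 log units; within the scatter), so this exchange of one substituted phenyl for another, the first here between two measured numbers, leaves compound 2 and compound 3 within the scatter of each other. Compound 3 also gives the first reading on where the methoxy group sits, and that reading is limited: 3-methoxyphenyl in place of 2-methoxyphenyl gives an at least 1.2-fold lower number from compound 1 to compound 3 (0.10 log units; that floor lies within the scatter), which can be read only as a floor because compound 1 stands at a limit of the assay: the limit of > 100000 nM in this assay, at which 1 of the 3 values shown sits. Across the two steps, then, neither the change from methyl to methoxy nor the change in the place of the methoxy group is shown to move the number beyond the scatter.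

On these data alone, all three compounds carry a substituted phenyl on this nitrogen, so it remains open whether a dimethylamino group, a carboxylic acid or a longer alkyl chain in that phenyl's substituent would shift the number in this assay. Also open, as far as these compounds go, is what a carbonyl in place of the thiocarbonyl would do, and whether any change to the shared core matters more than changes on this nitrogen.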